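A Hydroxyl Replaces the Nitrooxy Group on the Hydrazone Ring

The source may report more compounds than this note shows. Statements on the series, on what has been measured and on what is new or still open speak of the compounds shown alone.

Three close relatives share one core and differ only in the ring hanging from the hydrazone carbon. Compound 1 `CN(C)CCn1cnnc1-c1cc(Oc2ccc(NC(=O)N/N=C/c3ccccc3O[N+](=O)[O-])cc2F)ccn1` carries a 2-(nitrooxy)phenyl there; in a functional assay on MKN-45 cells (Homo sapiens) for cytotoxicity, read by MTT assay, with a stated time of 72 h (on this read-out lower numbers stand for stronger inhibition and higher numbers for weaker inhibition), compound 1 gives 1020 nM. Compound 2 `CN(C)CCn1cnnc1-c1cc(Oc2ccc(NC(=O)N/N=C/c3ccccc3)cc2F)ccn1` carries a plain phenyl and gives 2730 nM, while compound 3 `CN(C)CCn1cnnc1-c1cc(Oc2ccc(NC(=O)N/N=C/c3ccc(Cl)cc3)cc2F)ccn1` carries a 4-chlorophenyl and gives 570 nM. Among these three numbers compound 1 sits second highest, close to compound 3 and further from compound 2.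

Compound 4 `CN(C)CCn1cnnc1-c1cc(Oc2ccc(NC(=O)N/N=C/c3cccc(O)c3)cc2F)ccn1` is the new member. Its change from compound 1 is 3-hydroxyphenyl in place of 2-(nitrooxy)phenyl on a carbon with a double bond to nitrogen.

Two measured steps inform the outlook. Removing the nitrooxy group gave a 2.7-fold higher number from compound 1 to compound 2 (0.43 log units; beyond the scatter), and adding chloro gave a 4.8-fold lower number from compound 2 to compound 3 (0.68 log units; beyond the scatter). Among the measured compounds shown here, no measured compound carries a hydroxyl on this ring, so the effect of that group itself is unknown; what is known is that losing the nitrooxy group raised the number modestly. The expectation for compound 4 is therefore a modest rise from compound 1, estimated as a 1.8-fold higher number from compound 1 to compound 4 (0.25 log units; within the scatter), with wide uncertainty. Compound 4 is estimated to give 1800 nM in this assay, expected to fall between 600 nM and 5500 nM.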

Compound 4, half-maximal inhibitory concentration: 1370 nM
Beside the measured number, compound 4's estimate is 1.3-fold (0.12 log units) above it; the range from low to high includes it.
By their numbers in this assay, from the lowest: compounds 3, 1, 4 and 2 (each within the scatter of the next, the first and the last beyond it).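

In this assay the swap of 2-(nitrooxy)phenyl for 3-hydroxyphenyl gives a 1.3-fold higher number from compound 1 to compound 4 (0.13 log units; within the scatter), so at this carbon a ring without the nitrooxy group can read the same as compound 1 within the scatter, something the plain phenyl of compound 2 did not do. Adding the hydroxy group to that plain phenyl gives a 2.0-fold lower number from compound 2 to compound 4 (0.30 log units; within the scatter), a first reading for a hydroxyl on this ring, and it stays within the scatter, whereas chloro gave a 4.8-fold lower number from compound 2 to compound 3 (0.68 log units; beyond the scatter) as its step from the same parent. Against the 4-chlorophenyl, the 3-hydroxyphenyl gives a 2.4-fold higher number from compound 3 to compound 4 (0.38 log units; beyond the scatter), so among these rings the swap from chlorine to hydroxyl is a change that can be told apart from noise, although the group and its place on the ring differ together in that step.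

No supporting measurement explains why these rings read as they do. Still open, from the compounds shown here alone, is whether moving the hydroxyl elsewhere on the ring would alter the number, and how an amine or a carboxylic acid would read in its place.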